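The source may report more compounds than this note shows. Statements on the series, on what has been measured and on what is new or still open speak of the compounds shown alone.

Of the compounds shown here, two that share a core have been tested in a functional assay on MCF7 cells (Homo sapiens) for antiproliferative activity; on this read-out lower numbers stand for stronger inhibition and higher numbers for weaker inhibition. Compound 1 `CCCCn1c(Cc2cc(OC)c(OC)c(OC)c2)nc2c(N)nc(F)nc21` gives 24000 nM in this assay. Compound 2 `CC/C=C/Cn1c(Cc2cc(OC)c(OC)c(OC)c2)nc2c(N)ncnc21` gives 46800 nM in this assay, the higher of the two numbers shown, but its gap to compound 1 lies within the usual scatter of repeated measurements, so the two compounds cannot be told apart on these numbers. Both are weak inhibitors of cell growth.

Compound 3 `CCC(C)Cn1c(Cc2cc(OC)c(OC)c(OC)c2)nc2c(N)ncnc21` has not yet been measured in this assay. It differs from compound 2 in one place: sec-butyl in place of but-1-en-1-yl on a saturated chain carbon bound to an aromatic nitrogen. Going by the values given here, the chain stays the same size and keeps no ring; the only change is that the one double bond outside aromatic rings is gone and a sec-butyl group stands there instead. Among the compounds with values here, no measured pair shows what such a change does on this core, so the expectation rests on the two weak values alone. The step from compound 2 to compound 3 in this assay is expected to be small, a 1.2-fold lower number from compound 2 to compound 3 (0.07 log units; within the scatter), and not beyond the scatter in either direction. Compound 3 is therefore estimated to give about 40000 nM in this assay, with a likely range from 15000 nM to 110000 nM.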

Compound 3, half-maximal inhibitory concentration: 61700 nM
Beside the measured number, compound 3's estimate is 1.5-fold (0.19 log units) below it; measured number inside the range.
By their numbers in this assay, from the lowest: compounds 1, 2 and 3 (each within the scatter of the next, the first and the last beyond it).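

In this assay, compounds 2 and 3 are the only pair shown that differ in one place, and putting sec-butyl in place of but-1-en-1-yl on a saturated chain carbon bound to an aromatic nitrogen gives a 1.3-fold higher number from compound 2 to compound 3 (0.12 log units; within the scatter), so this change cannot be told apart from repeat-to-repeat noise. At this position, then, losing the one double bond outside aromatic rings, with the heavy-atom count of the group unchanged, leaves no measurable mark, and both compounds remain weak inhibitors of cell growth. Nothing available explains the outcome or links it to any property of either group.

On these data alone, one small step between two similar hydrocarbon groups does not show how much this position can matter, so it remains open whether an amine, a carboxylic acid, a phenyl ring or a much longer chain at the same place would shift the number beyond the scatter. As far as these compounds go, it is also open whether removing the double bond would give the same result on a version of the core that carries a further substituent.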